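This account rests on a few compounds, and the source may have more. Where it says the series, first, only, none or still open, it means among the compounds named here.

Compound 2 `Cc1nc(N)c2c(-c3cc4ccccc4o3)cn([C@@H]3O[C@H](CO)[C@@H](O)[C@H]3O)c2n1` is the starting point. In a functional assay on K562 cells (Homo sapiens), read by MTT assay, with a stated time of 72 h (on this read-out higher numbers stand for weaker inhibition and lower numbers for stronger inhibition), compound 2 gives 4990 nM. Compound 3 `Cc1ncnc2c1c(-c1ccsc1)cn2[C@@H]1O[C@H](CO)[C@@H](O)[C@H]1O` gives 5550 nM in this assay, a number within the scatter of that of compound 2, so the two cannot be ordered. For compound 1 `Nc1nc(N)c2c(-c3cc4ccccc4o3)cn([C@@H]3O[C@H](CO)[C@@H](O)[C@H]3O)c2n1` this assay reports only a limit, > 20000 nM. Of the two numbers, compound 2 stands lowest. Going by the values given here, the single measured step, an at least 4.0-fold lower number from compound 1 to compound 2 (0.60 log units; beyond the scatter), concerns methyl in place of amino and does not touch the group that changes here. Compound 4 `Cc1nc(N)c2c(I)cn([C@@H]3O[C@H](CO)[C@@H](O)[C@H]3O)c2n1` differs from compound 2 by iodo in place of 1-benzofuran-2-yl on an aromatic carbon. Among the compounds with values here, no measured step bears on this change, so the expectation carries a wide range; a higher number is expected. Compound 4 is estimated at 12000 nM, between 3000 nM and 40000 nM. The expected step is a 2.4-fold higher number from compound 2 to compound 4 (0.38 log units; beyond the scatter).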

Compound 4, half-maximal inhibitory concentration: 1110 nM
For compound 4 the middle estimate is 11-fold (1.03 log units) above the measured one, outside the stated range (below it).
By their numbers in this assay, from the lowest: compound 4; then compounds 2 and 3 (each within the scatter of the next). At a limit, above all of these: compound 1.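

In this assay, the change at this aromatic carbon gives a 4.5-fold lower number from compound 2 to compound 4 (0.65 log units; beyond the scatter), so here the 1-benzofuran-2-yl group is not required for the lower number, and a single iodo atom goes further. Going by these compounds alone, this is the first measured step at this position, as the earlier step concerned a different place. Nothing among the data shown accounts for this step.

Going by these compounds, how other groups on this carbon, such as bromo, ethynyl or an amine, would compare remains open. So does whether the step would hold with amino in place of methyl on the shared core.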